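The source may hold more compounds than are shown below. What is called first, only, known or untested is meant among the compounds shown, and "the series" means these compounds.

Working notes on the series. Compound 1 `N[C@]1(CO)CC[C@H](c2ccc3c(c2)CC[C@H](COCc2ccccc2)C3)C1` and compound 2 `COc1ccc(COC[C@@H]2CCc3cc([C@H]4CC[C@](N)(CO)C4)ccc3C2)cc1` share a core and differ in the group carried on the chain oxygen. In a functional assay on the whole organism (strain Lewis) with Rattus norvegicus as the target, with a stated time of 24 h, at a dose of 0.3 mg/kg by the oral route (on this read-out lower numbers stand for less inhibition and higher numbers for more inhibition at the one dose given (going by the name of the read-out)), compound 1 gives 0%, while compound 2 gives 33%, the higher of the two numbers, a gap beyond the scatter. Compound 3 `COc1cccc(COC[C@@H]2CCc3cc([C@H]4CC[C@](N)(CO)C4)ccc3C2)c1` is the next step from compound 2: 3-methoxyphenyl in place of 4-methoxyphenyl on a saturated chain carbon bound to an oxygen on a saturated carbon. Among the compounds with values here, no measured pair shows this change, so its size is open; a step from compound 2 to compound 3 of a number 6 percentage points lower from compound 2 to compound 3 (within the scatter) is expected, within the scatter. For compound 3 the estimate in this assay is 27%, with a range from 5% to 50%.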

Compound 3, a percentage reported as inhibition, in the whole organism at one dose (the size of the read-out at that dose, not a potency): 40%
Compound 3: middle estimate off by 13 percentage points, on the low side, and the stated range covers the measured number.
By their numbers in this assay, from the lowest: compound 1; then compounds 2 and 3 (each within the scatter of the next).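

In this assay, 3-methoxyphenyl in place of 4-methoxyphenyl on a saturated chain carbon bound to an oxygen on a saturated carbon gives a number 7 percentage points higher from compound 2 to compound 3 (within the scatter) and so does not separate the two compounds. Where the methoxy group sits on the phenyl ring, between these two placements, therefore makes no readable difference at this one dose. No available data explain this result.

Open, from the compounds shown here alone, is whether 2-methoxyphenyl or a chlorophenyl would read the same at this place. Going by these compounds, the response at other doses also remains open.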